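A Fluoro Substituent on the Hydrazide Compound 1

The compounds below may be only part of what the source reports. "The series", "measured", "known", "first", "only" and "open" are said of these compounds alone.

Compound 1 `NS(=O)(=O)c1ccc(C(=O)NNC(=O)c2ccccc2)cc1` is a benzoyl hydrazide carrying a sulfonamide. In an assay on cells for inhibition of Amine oxidase [flavin-containing] A (Homo sapiens), read by fluorescence and spectrophotometry, using microsomes, with a stated time of 20 min (on this read-out lower numbers stand for stronger inhibition and higher numbers for weaker inhibition), compound 1 gives 62800 nM. Compound 3 `NS(=O)(=O)c1ccc(-c2nnc(-c3ccc(Cl)c(Cl)c3)o2)cc1` gives 46200 nM in this assay, a number that sits within the scatter of the number for compound 1, so the two cannot be separated. Compound 2 `N#Cc1ccc(-c2nnc(-c3ccc(S(N)(=O)=O)cc3)o2)cc1` gives 24300 nM in this assay, which falls beyond the scatter on the lower side of compound 1. Compound 2 and compound 3 share a core that compound 1 does not have, so neither gives a single-point comparison with it.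

Compound 4 `NS(=O)(=O)c1ccc(C(=O)NNC(=O)c2ccc(F)cc2)cc1` differs from compound 1 by fluoro in place of hydrogen on an aromatic carbon. Within the data shown here, no measured pair in this set shows this change, so there is no step to lean on. Compound 4 is expected to stay close to compound 1, with a step of a 1.1-fold lower number from compound 1 to compound 4 (0.06 log units; within the scatter) that remains within the scatter and has no clear direction. For compound 4 in this assay the expected value is 55000 nM, with a range from 20000 nM to 150000 nM.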

Compound 4, half-maximal inhibitory concentration: 39600 nM
Beside the measured number, compound 4's estimate is 1.4-fold (0.14 log units) above it; the range from low to high includes it.
By their numbers in this assay, from the lowest: compounds 2, 4, 3 and 1 (each within the scatter of the next, the first and the last beyond it).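

In this assay, among these compounds, the change from phenyl to 4-fluorophenyl gives a 1.6-fold lower number from compound 1 to compound 4 (0.20 log units; within the scatter), the first step in this set that isolates a single place on the hydrazide series. Fluoro in place of hydrogen at this aromatic carbon therefore leaves compound 4 inseparable from compound 1, and no direction can be assigned to the change from this one pair. The compounds shown offer no measured information that could explain this result.

As far as these compounds go, whether this position responds at all remains open, since a single small substituent cannot show whether a larger or charged group, such as an amine or a carboxylic acid, would carry the number beyond the scatter. From the compounds shown here alone, it also remains open whether fluoro on another carbon of the same ring would give a different result.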